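Swapping the sulfur oxidation state on a phenyl ring

A few compounds are considered here, and "the series" means these few. Any claim that something is new, unique, unknown or untested is made for them only; others in the source may bear on it.

Among the measured compounds shown here, compound 2 `CS(=O)(=O)c1ccc(Cl)cc1NCC1=NCCN1` has the higher of the two numbers so far measured in a functional assay for agonist activity at Alpha-1A adrenergic receptor (Homo sapiens) (a higher number here means that more compound is needed for the effect, a lower number that less compound is needed), where compound 2 gives 2.82 nM. Its nearest neighbour is compound 1 `CSc1ccc(F)cc1NCC1=NCCN1`, which in this assay gives 2.29 nM, a gap that lies within the scatter. Compound 3 `CSc1ccc(Cl)cc1NCC1=NCCN1` arises from compound 2 by one change: methylsulfanyl in place of methylsulfonyl on an aromatic carbon. For the measured compounds named here, no measured pair shows this exact step, so no step beyond the scatter is expected from compound 2 to compound 3 in this assay, which is what a 1.1-fold lower number from compound 2 to compound 3 (0.05 log units; within the scatter) means. Compound 3 is therefore estimated at 2.5 nM, in the range 1 nM to 6.5 nM.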

Compound 3, half-maximal effective concentration: 0.437 nM
The estimate for compound 3 lay 5.7-fold (0.76 log units) above the measured number, outside the stated range (below it).
By their numbers in this assay, from the lowest: compound 3; then compounds 1 and 2 (each within the scatter of the next).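

In this assay, methylsulfanyl in place of methylsulfonyl on the aromatic carbon para to a chloro group gives a 6.5-fold lower number from compound 2 to compound 3 (0.81 log units; beyond the scatter) and so shows that this position responds to the sulfur group when the rest is held fixed. With methylsulfanyl kept, chloro in place of fluoro gives a 5.2-fold lower number from compound 1 to compound 3 (0.72 log units; beyond the scatter) as a second step beyond the scatter. Nothing available explains either step.

As far as these compounds go, it remains open how methylsulfinyl, methoxy or a longer chain such as ethylsulfanyl would compare at this position, and whether the sulfur step carries over with fluoro in place of chloro.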